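Replacing the aryl group of compound 3 with chloro

The compounds below may be only part of what the source reports. "The series", "measured", "known", "first", "only" and "open" are said of these compounds alone.

Measured so far:
- compound 1 `Cc1ccc(-c2cc(C(=O)N3CCC4(CC3)CC(=O)c3nn(C(C)(C)C)cc3O4)c3ccccc3n2)cc1` gives 5300 nM
- compound 2 `CC(C)(C)n1cc2c(n1)C(=O)CC1(CCN(C(=O)c3cc(-c4ccc(Br)cc4)nc4ccccc34)CC1)O2` gives 9300 nM
- compound 3 `CN(C)c1ccc(-c2cc(C(=O)N3CCC4(CC3)CC(=O)c3nn(C(C)(C)C)cc3O4)c3ccccc3n2)cc1` gives 1150 nM

All three values come from a functional assay on A549 cells (Homo sapiens) for inhibition, read by MTT assay, with a stated time of 72 h; on this read-out lower numbers stand for stronger inhibition and higher numbers for weaker inhibition. Compound 3 holds the lowest number of the set, and both gaps to it lie beyond the scatter: a 4.6-fold lower number from compound 1 to compound 3 (0.66 log units; beyond the scatter) and an 8.1-fold lower number from compound 2 to compound 3 (0.91 log units; beyond the scatter). The remaining step, a 1.8-fold higher number from compound 1 to compound 2 (0.24 log units; within the scatter), lies within the scatter, so compound 1 and compound 2 are not separated.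

Compound 4 `CC(C)(C)n1cc2c(n1)C(=O)CC1(CCN(C(=O)c3cc(Cl)nc4ccccc34)CC1)O2` changes compound 3 as follows: chloro in place of 4-(dimethylamino)phenyl on an aromatic carbon. This is chloro in place of 4-(dimethylamino)phenyl on an aromatic carbon, next to the ring nitrogen. The measured steps only exchange a group on the six-membered aromatic ring of carbon only, and all three compounds keep that ring. No measurement therefore shows what removing it does, and the expectation is loose.

The nearest guide is the step that brings in the dimethylamino group, a 4.6-fold lower number from compound 1 to compound 3 (0.66 log units; beyond the scatter), read here in the opposite direction. A step of similar or somewhat larger size towards a higher number is expected in this assay. The expected step is a 6.1-fold higher number from compound 3 to compound 4 (0.78 log units; beyond the scatter). For compound 4 the estimated value is 7000 nM, with an expected range from 2000 nM to 25000 nM.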

Compound 4, half-maximal inhibitory concentration: 7170 nM
Beside the measured number, compound 4's estimate is 1.0-fold (0.01 log units) below it; the measured number falls inside the stated range.
By their numbers in this assay, from the lowest: compound 3; then compounds 1, 4 and 2 (each within the scatter of the next).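

In this assay, putting chloro on this carbon next to the ring nitrogen in place of 4-(dimethylamino)phenyl gives a 6.2-fold higher number from compound 3 to compound 4 (0.79 log units; beyond the scatter) and so removes the advantage held by compound 3 in this set. The other two aryl groups are not separated from chloro, since a 1.3-fold lower number from compound 2 to compound 4 (0.11 log units; within the scatter) and a 1.4-fold higher number from compound 1 to compound 4 (0.13 log units; within the scatter) both lie within the scatter, which means that a six-membered aromatic ring of carbon only at this position does not by itself lower the number, and among these four compounds only the 4-(dimethylamino)phenyl group stands apart. No measurement on hand accounts for this difference.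

On these data alone, it remains open whether the dimethylamino group needs the intervening aromatic ring, which a dimethylamino or morpholine group placed directly on this carbon would test against compound 4. As far as these compounds go, it is also open whether the nitrogen substituent on the aryl ring matters specifically, which a 4-aminophenyl, 4-methoxyphenyl or 4-(morpholin-4-yl)phenyl group would help to show alongside compound 3.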